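The source may hold more compounds than are shown below. What is called first, only, known or untested is meant among the compounds shown, and "the series" means these compounds.

Measured in a functional assay on PC-3 cells (Homo sapiens) for antiproliferative activity, read by MTT assay, with a stated time of 72 h; on this read-out higher numbers stand for weaker inhibition and lower numbers for stronger inhibition:
- compound 1 `CCN(CC)CCNC(=O)c1ccc(C(CC)(CC)c2ccc(OCC(O)C(C)(C)C)c(C)c2)n1CC`: 2800 nM
- compound 2 `CCn1c(C(=O)NCCC(=O)OC)ccc1C(CC)(CC)c1ccc(C#CC(O)(CC)CC)c(C)c1`: 36300 nM

Compound 2 gives 36300 nM, the higher of the two numbers and beyond the scatter from compound 1, although the two differ in more than one place. Compound 3 `CCN(CC)CCCNC(=O)c1ccc(C(CC)(CC)c2ccc(C#CC(O)(CC)CC)c(C)c2)n1CC` departs from compound 2 by (diethylamino)methyl in place of methoxycarbonyl on a saturated chain carbon, two bonds along the chain from an amide-type nitrogen. A lower number, beyond the scatter, is expected in this assay. This expectation rests on compound 1 at 2800 nM, which also carries a diethylamino group. The expected step is a 7.3-fold lower number from compound 2 to compound 3 (0.86 log units; beyond the scatter). The estimate for compound 3 is 5000 nM, with an expected range of 1500 nM to 18000 nM.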

Compound 3, half-maximal inhibitory concentration: 8500 nM
Compound 3: middle estimate off by 1.7-fold (0.23 log units), on the low side, and the stated range covers the measured number.
By their numbers in this assay, from the lowest: compound 1; then compound 3; then compound 2.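

In this assay, (diethylamino)methyl in place of methoxycarbonyl on a saturated chain carbon, two bonds along the chain from an amide-type nitrogen, gives a 4.3-fold lower number from compound 2 to compound 3 (0.63 log units; beyond the scatter). This single change, with the rest of the structure held constant, shows that the read-out responds to the group at this position. No measurement on hand accounts for the step.

Going by these compounds, it remains open whether the amine itself carries the step, as a carboxylic acid or a neutral amide at this place could help to show. On these data alone, the effect of a longer chain or a morpholine in place of diethylamino also remains open.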